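This account rests on a few compounds, and the source may have more. Where it says the series, first, only, none or still open, it means among the compounds named here.

Measured so far:
- Compound 1 `Cc1ccc(-c2nc3ccccn3c2Sc2ccccc2)cc1`: > 100000 nM
- Compound 2 `c1ccc(Sc2c(-c3cccc4ccccc34)nc3ccccn23)cc1`: > 100000 nM
- Compound 3 `c1ccc(Sc2c(-c3ccccc3)nc3ccc(-c4ccccc4)cn23)cc1`: > 100000 nM

The compounds were tested in a functional assay on U-87MG ATCC cells for inhibition, with U-87 MG (Homo sapiens) as the target, read by MTT assay, with a stated time of 48 h; a higher number here means a weaker inhibitor, a lower number a stronger inhibitor. Compound 1 gives > 100000 nM, which is a limit of the assay and not a number. The other two readings are limits as well, so compound 1 has no measured position relative to them. The whole set shares one result: the limit of > 100000 nM in this assay, at which 3 of the 3 values shown sit.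

Compound 4 `CSc1ccc(-c2nc3ccccn3c2Sc2ccccc2)cc1` has not yet been measured. It differs from compound 1 in one place: methylsulfanyl in place of methyl on an aromatic carbon. Methylsulfanyl stands in place of methyl on an aromatic carbon of a six-membered aromatic ring of carbon only, para to a large group. The same difference can be read as 4-methylphenyl to 4-(methylsulfanyl)phenyl.

For the measured compounds named here, no two measured compounds differ in just one place, so the data show no size for a single change. The expectation therefore rests on compound 1, whose > 100000 nM is a limit. No step beyond the usual scatter is expected in this assay, and compound 4 is likely to report only a limit too. The expected change is a number no higher from compound 1 to compound 4 (the limit leaves the size open). For compound 4 the estimated value is 100000 nM, with an expected range from 30000 nM to 150000 nM.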

Compound 4, half-maximal inhibitory concentration: 26900 nM
The estimate for compound 4 lay 3.7-fold (0.57 log units) above the measured number; the measured number lies below the stated range.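

In this assay, for the compounds shown here, swapping the methyl group for a methylsulfanyl group, para to a large group, gives an at least 3.7-fold lower number from compound 1 to compound 4 (0.57 log units; beyond the scatter), the first change here that can be read as a step at all. Compound 1 gives > 100000 nM, which is a limit and not a number, so this step has a floor but no known full size. The position therefore responds to what is placed on it, with compound 4 as the only compound shown that reads as a number rather than a limit: the limit of > 100000 nM in this assay, at which 3 of the 4 values shown sit.

One pair cannot separate the part played by the sulfur from that of the added heavy atom, and it does not show whether other groups in this place, such as methoxy, an amine, a carboxylic acid or a longer chain, would lower the number further, leave it at the limit or do something else. On these data alone, it also remains open whether methylsulfanyl would have a similar effect on the core of compound 3, which differs from compound 1 in more than one place.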